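Notes on the chain extension to compound 4

The source may report more compounds than this note shows. Statements on the series, on what has been measured and on what is new or still open speak of the compounds shown alone.

In an in vitro functional assay on cells for agonist activity at Bombesin receptor subtype-3 (Homo sapiens), read by luminescence and calcium flux (a higher number here means that more compound is needed for the effect, a lower number that less compound is needed), compound 3 `CC(C)CCc1cnc(CCc2ccc(-c3ccccc3C(=O)O)cc2)[nH]1` gives 119 nM, the lowest of the three numbers. Compound 1 `Cc1ccccc1Cc1cnc(CCc2ccc(-c3ccccc3C(=O)O)cc2)[nH]1` gives 127 nM; the step of a 1.1-fold lower number from compound 1 to compound 3 (0.03 log units; within the scatter) lies within the scatter, so the two are not distinguished. Compound 2 `O=C(O)c1ccccc1-c1ccc(CCc2ncc(Cc3ccc(Cl)cc3)[nH]2)cc1` gives 2290 nM, and the step of a 19-fold lower number from compound 2 to compound 3 (1.28 log units; beyond the scatter) is large. Compound 4 `CC(C)(C)CCc1cnc(CCc2ccc(-c3ccccc3C(=O)O)cc2)[nH]1` carries methyl in place of hydrogen on a saturated chain carbon bound to three saturated chain carbons, the isobutyl becoming neopentyl. For the measured compounds named here, no measured step alters a saturated chain alone; the two steps into compound 3 only show that isobutyl and 2-methylphenyl give like numbers while 4-chlorophenyl gives a far higher one. A small extension of an accepted chain is therefore expected to move this assay little: the estimated step of a 1.3-fold higher number from compound 3 to compound 4 (0.10 log units; within the scatter) stays within the scatter. Compound 4 is estimated at 150 nM, between 50 nM and 450 nM.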

Compound 4, half-maximal effective concentration: 39 nM
Compound 4: the middle estimate sits 3.8-fold (0.59 log units) above what was measured, outside the stated range (below it).
By their numbers in this assay, from the lowest: compound 4; then compounds 3 and 1 (each within the scatter of the next); then compound 2.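

In this assay, methyl in place of hydrogen on a saturated chain carbon bound to three saturated chain carbons shows that this chain still responds to a one-carbon change, with a 3.1-fold lower number from compound 3 to compound 4 (0.48 log units; beyond the scatter) for isobutyl to neopentyl. Neopentyl also separates from the aromatic groups, which isobutyl did not do for 2-methylphenyl: the steps are a 3.3-fold lower number from compound 1 to compound 4 (0.51 log units; beyond the scatter) and a 59-fold lower number from compound 2 to compound 4 (1.77 log units; beyond the scatter). No evidence on the origin of these differences is available.

From the compounds shown here alone, whether a longer chain or a cyclohexyl group at this place lowers the number further stays open. So does whether an amine in the chain is accepted.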